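The compounds below may be only part of what the source reports. "The series", "measured", "known", "first", "only" and "open" are said of these compounds alone.

Working notes on a pair of measured compounds and one awaiting data. Compound 1 `COc1ccc(OC)c(/C=C/c2nnc(Nc3ccc(Cl)cc3)o2)c1` and compound 2 `COc1ccc(OC)c(/C=C/C(=O)N/N=C/c2ccc(Cl)cc2)c1` share a common part of the structure but differ in how the shared core is joined to the chlorine-bearing ring. In a functional assay on SNB-75 cells (Homo sapiens) for antiproliferative activity, read by sulforhodamine B assay, with a stated time of 48 h (a lower number here means a stronger inhibitor of growth, a higher number a weaker inhibitor of growth), compound 1 gives 2260 nM, and in this assay compound 2 gives 98 nM. On these two numbers compound 2 holds the lower value, and its gap to compound 1 lies beyond the scatter, so compound 2 is the more potent of the pair as far as the numbers shown go.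

Compound 3 `COc1ccc(OC)c(/C=C/C(=O)N/N=C/c2ccccc2)c1` has not yet been measured. It differs from compound 2 by hydrogen in place of chloro on an aromatic carbon; in words, hydrogen in place of chloro on an aromatic carbon, the place being para to a large group on the six-membered aromatic ring of carbon only. Within the data shown here, no pair of measured compounds differing at that place alone is available, so the size of the step cannot be read from earlier data. A small loss is expected, of a size near the edge of the scatter. For compound 3 the expected value in this assay is 200 nM, with a range from 60 nM to 700 nM. The step from compound 2 to compound 3 is thus expected to be a 2.0-fold higher number from compound 2 to compound 3 (0.31 log units; beyond the scatter).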

Compound 3, concentration for 50% growth inhibition: 4390 nM
Estimate against measurement, compound 3: 22-fold (1.34 log units) below, outside the stated range (above it).
By their numbers in this assay, from the lowest: compound 2; then compounds 1 and 3 (each within the scatter of the next).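

In this assay, among these compounds, hydrogen in place of chloro on an aromatic carbon, the change from 4-chlorophenyl to phenyl, gives a 45-fold higher number from compound 2 to compound 3 (1.65 log units; beyond the scatter) as the first step that can be read at a single place. The potency of compound 2 therefore does not rest on the shared parts of the structure alone: with everything else held constant, the loss of one chlorine atom from this place on the six-membered aromatic ring of carbon only, para to a large group, accounts for a large loss of growth inhibition. The compounds at hand offer no measurement that bears on the reason for a step of this size.

As far as these compounds go, whether this place favours chloro in particular or would also accept another group stays open, since fluoro, bromo, methyl, methoxy or an amine at the same place would each test that question directly. Among the compounds shown here, also open is whether the same change would produce a step of similar size on the core of compound 1, for which no step at this place can be read.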